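From butyl to 4-methylphenyl on the aromatic nitrogen

The source may hold more compounds than are shown below. What is called first, only, known or untested is meant among the compounds shown, and "the series" means these compounds.

In a functional assay on HeLa cells (Homo sapiens) for antiproliferative activity, read by MTT assay, with a stated time of 72 h (on this read-out higher numbers stand for weaker inhibition and lower numbers for stronger inhibition), compound 1 (`CCn1ccnc1-c1cc(OC)c(OC)c(OC)c1`) gives > 100000 nM, which is a limit of the assay. Compound 2 (`CCCCn1ccnc1-c1cc(OC)c(OC)c(OC)c1`) gives > 100000 nM, which is also a limit. Compound 2 therefore stands at the limit of > 100000 nM in this assay, at which 2 of the 3 values shown sit, and the chain extension is a step that the two limits leave unreadable from compound 1 to compound 2. No step size can be carried over from it. Among the compounds with values here, compound 3 (`COc1cc(-c2nccn2-c2ccc3cc[nH]c3c2)cc(OC)c1OC`) is the only measured compound with a numerical value, at 4800 nM.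

Compound 4 (`COc1cc(-c2nccn2-c2ccc(C)cc2)cc(OC)c1OC`) replaces the chain of compound 2: 4-methylphenyl in place of butyl on an aromatic nitrogen. In words, 4-methylphenyl stands in place of butyl on an aromatic nitrogen. With no chain on that nitrogen, compound 4 is expected to fall nearer compound 3 at 4800 nM, although this rests on a single value. The expected change is an at least 11-fold lower number from compound 2 to compound 4 (1.04 log units; beyond the scatter), in the direction of stronger inhibition in this assay. Compound 4 is estimated at 9000 nM, with an expected range of 1500 nM to 60000 nM.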

Compound 4, half-maximal inhibitory concentration: 700 nM
The estimate for compound 4 lay 13-fold (1.11 log units) above the measured number, outside the stated range (below it).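

Within the data shown here, replacing the chain on the aromatic nitrogen with 4-methylphenyl gives the first readable change at this position: an at least 140-fold lower number from compound 2 to compound 4 (2.15 log units; beyond the scatter), and likewise an at least 140-fold lower number from compound 1 to compound 4 (2.15 log units; beyond the scatter), while the step between the two chains cannot be read. Both compounds shown with a six-membered aromatic ring system on that nitrogen give numerical values in this assay: compound 3 gives 4800 nM and compound 4 gives 700 nM. The steps remain bounds rather than exact sizes, and the limit for compound 2 sets that bound: the limit of > 100000 nM in this assay, at which 2 of the 4 values shown sit.

Still open, from the compounds shown here alone, is whether the change depends on the aromatic ring itself or on its 4-methyl group, which unsubstituted phenyl on the same nitrogen would help to separate. Also open, going by these compounds, is whether benzyl, with a carbon linking the ring to that nitrogen, keeps the numerical activity of compound 4.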